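Chloro for Methoxy in a Cytotoxicity Series

The source may report more compounds than this note shows. Statements on the series, on what has been measured and on what is new or still open speak of the compounds shown alone.

Compound 1 `COc1ccc(CSc2nnc(-c3cc([N+](=O)[O-])cc([N+](=O)[O-])c3)n2C)cc1`: in an ADME assay on A-431 cells (Homo sapiens) for cytotoxicity, with a stated time of 48 h (a higher number here means a weaker inhibitor, a lower number a stronger inhibitor), compound 1 gives > 30000 nM, which is a limit of the assay.
Compound 2 `Cn1c(SCc2ccc(Cl)cc2)nnc1-c1cc([N+](=O)[O-])cc([N+](=O)[O-])c1`: in this assay compound 2 gives > 30000 nM, also a limit.
Compound 3 `COc1ccc(CSc2nnc(-c3cc([N+](=O)[O-])cc(C(F)(F)F)c3)n2Cc2ccccc2)cc1`: in this assay compound 3 gives > 30000 nM, again a limit.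

Compound 2 differs from compound 1 by chloro in place of methoxy on an aromatic carbon. The step this made, a step that the two limits leave unreadable from compound 1 to compound 2, cannot be sized, since (the limit of > 30000 nM in this assay, at which 3 of the 3 values shown sit). Compound 3 has a different core from compound 1; that difference is not broken down here. Compound 4 `O=[N+]([O-])c1cc(-c2nnc(SCc3ccc(Cl)cc3)n2Cc2ccccc2)cc(C(F)(F)F)c1` differs from compound 3 by chloro in place of methoxy on an aromatic carbon. The place is described in the same words for both pairs, so this is the same change, made here for the second time among the compounds shown. For compound 4 the expected step is a step that the limit leaves unreadable from compound 3 to compound 4, set beside the earlier one. It rests on compound 3, whose value > 30000 nM is a limit. It rests also on the earlier change leaving nothing readable in a step that the two limits leave unreadable from compound 1 to compound 2. Compound 4 is therefore expected at about 50000 nM, from 20000 nM to 150000 nM, and most likely reported again only as a limit.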

Compound 4, half-maximal inhibitory concentration: > 30000 nM
Compound 4: no number, only a limit (the forecaster's own chance of this, stated with the estimate: 80%); the middle value is on the limit's open side.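

In this assay compound 4 gives > 30000 nM, again a limit and not a number. No size can be given for the step from compound 3 to compound 4 because both compounds sit at the same limit: the limit of > 30000 nM in this assay, at which 4 of the 4 values shown sit.

The compounds shown leave open whether chloro in place of methoxy changes the half-maximal inhibitory concentration at all, and what that concentration is for any of the four.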